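The source may hold more compounds than are shown below. What is called first, only, known or untested is meant among the compounds shown, and "the series" means these compounds.

Compound 1 `COc1cccc(CCOc2ccc(-c3c(C)nc(C)c([C@H](OC(C)(C)C)C(=O)O)c3N3CCC(C)(C)CC3)cc2)c1`: in an ADME assay on microsomes from liver (Homo sapiens) for metabolic stability, read by LC-MS, tested at 0.5 uM (on this read-out higher numbers stand for a longer-lived compound and lower numbers for a shorter-lived compound), compound 1 gives > 2 h, which is a limit of the assay and not a number.
Compound 2 `Cc1cc(CCOc2ccc(-c3c(C)nc(C)c([C@H](OC(C)(C)C)C(=O)O)c3N3CCC(C)(C)CC3)cc2)ccc1F`: in this assay compound 2 gives > 2 h, again a limit.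
Compound 3 `Cc1nc(C)c([C@H](OC(C)(C)C)C(=O)O)c(N2CCC(C)(C)CC2)c1-c1ccc(CCCc2ccc(F)cc2)cc1`: in this assay compound 3 gives > 2 h, also a limit.

Compound 3 thus stands at the same limit as every other value shown (the limit of > 2 h in this assay, at which 3 of the 3 values shown sit). The steps a step that the two limits leave unreadable from compound 1 to compound 3 and a step that the two limits leave unreadable from compound 2 to compound 3 are unreadable in size, as is a step that the two limits leave unreadable from compound 1 to compound 2. Compound 4 `Cc1ccc(CCOc2ccc(-c3c(C)nc(C)c([C@H](OC(C)(C)C)C(=O)O)c3N3CCC(C)(C)CC3)cc2)s1` differs from compound 3 by 2-(5-methylthiophen-2-yl)ethoxy in place of 3-(4-fluorophenyl)propyl on an aromatic carbon. For the measured compounds named here, no measured step gives a readable size, so no direction can be read for it in this assay; the step to compound 4 is expected as a step that the limit leaves unreadable from compound 3 to compound 4. Compound 4 is therefore estimated at 2.5 h in this assay, within 1 h to 5 h, most likely reported again only as a limit.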

Compound 4, half-life: > 2 h
Compound 4: only a limit was reported; the forecaster's own chance of this, stated with the estimate: 65%; the middle value is on the limit's open side.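

In this assay compound 4 gives > 2 h, a limit and not a number. The steps to compound 4 from compound 1, compound 2 and compound 3 cannot be read: the limit of > 2 h in this assay, at which 4 of the 4 values shown sit.

From the compounds shown here alone, how the half-lives of these four compounds rank, and how far each lies past the limit, remains open.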